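The source may hold more compounds than are shown below. What is called first, only, known or untested is meant among the compounds shown, and "the series" means these compounds.

Measured in an ADME assay on J774 cells (Mus musculus) for antiproliferative activity, with a stated time of 72 h; on this read-out lower numbers stand for an effect already at smaller amounts and higher numbers for an effect only at larger amounts of compound:

Compound 1 `CCCCc1cc2c(=O)c(CC)c(C)[nH]c2cc1OCCOc1ccccc1`: 1000 nM
Compound 2 `CCc1c(C)[nH]c2cc(OCCOc3ccccc3)c(Cl)cc2c1=O`: > 28000 nM (a limit)
Compound 3 `CCc1c(C)[nH]c2cc(OCCOc3ccccc3)c(C)cc2c1=O`: > 30000 nM (a limit)

In this assay compound 3 gives > 30000 nM, which is a limit and not a number. Compound 4 `CCc1c(C)[nH]c2cc(OCCOc3ccccc3)c(OC)cc2c1=O` differs from it by methoxy in place of methyl on an aromatic carbon.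

Three measured steps involve this same place. Chloro in place of butyl gave an at least 28-fold higher number from compound 1 to compound 2 (1.44 log units; beyond the scatter), and shortening butyl to methyl gave an at least 30-fold higher number from compound 1 to compound 3 (1.47 log units; beyond the scatter). Going by the values given here, both steps are large and lead away from the only compound with a number. Methyl in place of chloro gave a step that the two limits leave unreadable from compound 2 to compound 3, so the data show nothing about how far small groups here differ from one another. Compound 4 also lacks butyl, so it is expected to stay close to compound 2 and compound 3, most likely as a limit again.

The expected change is a number no higher from compound 3 to compound 4 (the limit leaves the size open), which means no step beyond the scatter is foreseen. Compound 4 is estimated at 30000 nM, with an expected range from 12000 nM to 60000 nM.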

Compound 4, half-maximal effective concentration: > 29000 nM
Compound 4: only a limit was reported; the forecaster's own chance of this, stated with the estimate: 85%; the middle value lies beyond the limit too.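

In this assay, methoxy joins chloro and methyl as a third small group at this place, ortho to a large group, and it brings in an oxygen and a hydrogen-bond acceptor that methyl lacks, yet it still yields no number. Compound 4 is reported only as a limit: the limit of > 29000 nM in this assay, at which 1 of the 4 values shown sits. Methoxy in place of butyl gives an at least 29-fold higher number from compound 1 to compound 4 (1.46 log units; beyond the scatter), while the steps among compound 2, compound 3 and compound 4 cannot be read, each joining two limits.

As far as these compounds go, of these four, only compound 1 gives a number, 1000 nM, so it remains open whether that activity depends on the length of the chain at this place. From the compounds shown here alone, a propyl or pentyl chain, or an aminoalkyl chain ending in an amine, would test this, and how the small groups differ from one another also stays unknown.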